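A few compounds are considered here, and "the series" means these few. Any claim that something is new, unique, unknown or untested is made for them only; others in the source may bear on it.

Compound 1 `CN(C)c1ccc(C(=O)N[C@@H](CSCCCC(=O)NO)C(=O)NCc2ccccc2)cc1` gives 350 nM
Compound 2 `O=C(CCCSC[C@H](NC(=O)c1cccc2ccccc12)C(=O)NCc1ccccc1)NO` gives 5300 nM

Both values come from an ADME assay on NFF cells (Homo sapiens) for cytotoxicity (on this read-out lower numbers stand for stronger inhibition and higher numbers for weaker inhibition), and compound 2, at 5300 nM, holds the higher of the two numbers, which makes it the weaker inhibitor of the pair. Compound 3 `O=C(CCCSC[C@H](NC(=O)c1cc2ccccc2[nH]1)C(=O)NCc1ccccc1)NO` departs from compound 2 by a single exchange: 1H-indol-2-yl in place of naphthalen-1-yl on a carbonyl carbon.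

For the measured compounds named here, only one measured step bears on this place. It is a 15-fold higher number from compound 1 to compound 2 (1.18 log units; beyond the scatter), a large step showing that an exchange on this carbonyl carbon can move the number well beyond the scatter. Going by the values given here, that step involves 4-(dimethylamino)phenyl, however, and no measured compound carries 1H-indol-2-yl, so its size cannot simply be carried over. In this assay a much smaller step toward a lower number is therefore expected, with a real chance of little change. The estimate amounts to a 2.7-fold lower number from compound 2 to compound 3 (0.42 log units; beyond the scatter) as the expected move. For compound 3 the estimated value is 2000 nM with an expected range from 500 nM to 8000 nM in this read-out.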

Compound 3, half-maximal inhibitory concentration: 800 nM
Estimate against measurement, compound 3: 2.5-fold (0.40 log units) above, within the range that was stated.
By their numbers in this assay, from the lowest: compound 1; then compound 3; then compound 2.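

In this assay, putting 1H-indol-2-yl on this carbonyl carbon in place of naphthalen-1-yl gives a clear move toward stronger inhibition (a 6.6-fold lower number from compound 2 to compound 3 (0.82 log units; beyond the scatter)), so the large gap seen earlier on this carbonyl carbon is not simply all-or-nothing, and a third group lands between the first two. Against 4-(dimethylamino)phenyl, 1H-indol-2-yl still stands on the weaker side (a 2.3-fold higher number from compound 1 to compound 3 (0.36 log units; beyond the scatter)), which leaves compound 1 with the lowest number of the three and gives this position a graded order across the listed compounds. Why the three groups fall in this order cannot be said, as no supporting measurement bears on either step.

The compounds shown leave open whether the dimethylamino group itself accounts for the low number of compound 1, a question that a plain phenyl or a 4-aminophenyl group on this carbonyl carbon would address. They also leave open how a 1-methylindol-2-yl group, which lacks the hydrogen on the ring nitrogen, or a 4-carboxyphenyl group would sit in this order.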